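Methyl branch on the chain carbon of compound 1

The source may report more compounds than this note shows. Statements on the series, on what has been measured and on what is new or still open speak of the compounds shown alone.

Working notes on the series. Compound 1 `C[C@H](Nc1nc2cc(Cl)c(F)cc2s1)c1ccccc1` is one of three compounds with a number in a functional assay on Ehrlich cells (Mus musculus) for cytotoxicity, read by MTT assay, with a stated time of 24 h (a lower number here means a stronger inhibitor, a higher number a weaker inhibitor), where compound 1 gives 36600 nM. Compound 2 `CCCCCC[C@@H](C)NC(=S)Nc1ccc(F)c(Cl)c1` is built differently and in this assay compound 2 gives 25500 nM. Compound 3 `CCCCCC[C@@H](C)Nc1nc2cc(Cl)c(F)cc2s1` shares the core of compound 1 but carries a different chain, and in this assay compound 3 gives 24600 nM. Compound 1 holds the highest of the three numbers, yet its gaps to compound 2 and to compound 3 both lie within the scatter of repeated measurements, so the three compounds stand together and no order among them can be read.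

Compound 4 `CC[C@H](Nc1nc2cc(Cl)c(F)cc2s1)c1ccccc1` differs from compound 1 in one place: methyl in place of hydrogen on a saturated chain carbon, two bonds along the chain from an aromatic carbon and a nitrogen on an aromatic ring. Going by the values given here, no pair of measured compounds shows this change, so the series gives no precedent for its size or direction. The expectation is a step no larger than the scatter, with no set direction. The step of a 1.2-fold lower number from compound 1 to compound 4 (0.09 log units; within the scatter) is therefore estimated to stay within the scatter. Compound 4 is estimated at 30000 nM in this assay, with a range from 12000 nM to 75000 nM.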

Compound 4, half-maximal inhibitory concentration: 32200 nM
Compound 4: middle estimate off by 1.1-fold (0.03 log units), on the low side; measured number inside the range.
By their numbers in this assay, from the lowest: compounds 3, 2, 4 and 1 (each within the scatter of the next).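

In this assay, going by these compounds alone, the change from methyl to ethyl on this saturated chain carbon gives a 1.1-fold lower number from compound 1 to compound 4 (0.06 log units; within the scatter) and thereby supplies the first measured precedent for this change. Adding one carbon at this position, with the phenyl group and the rest of compound 1 left as they stand, therefore produces no step beyond the scatter, and with a single pair inside the scatter no direction can be assigned to the change. No measured property or other supporting data bear on this result, so no cause can be assigned to it.

Still open, going by these compounds, is whether a longer chain such as propyl or butyl, or a small ring such as cyclopropyl, at this carbon would produce a step beyond the scatter or would likewise stay within it. Also open, on these data alone, is how a chain carrying a hydroxyl group, an amine or a carboxylic acid at this position would read in this assay, and whether the opposite configuration at this carbon would give a different number.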